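The source may report more compounds than this note shows. Statements on the series, on what has been measured and on what is new or still open speak of the compounds shown alone.

Measured so far in a functional assay on MGC-803 cells (Homo sapiens) for antiproliferative activity, read by MTT assay, with a stated time of 48 h; on this read-out higher numbers stand for weaker inhibition and lower numbers for stronger inhibition:
Compound 1 `COc1ccc(CN(C(=O)CSc2ccccn2)c2cc(OC)c(OC)c(OC)c2)cc1` gives 2410 nM
Compound 2 `COc1ccc(CN(C(=O)CSC2=CN=NC2C)c2cc(OC)c(OC)c(OC)c2)cc1` gives 2960 nM

Compound 2 lies within the scatter of compound 1, so the two cannot be ranked. Compound 3 `COc1ccc(CN(C(=O)CSc2nc3ccc(OC)cc3s2)c2cc(OC)c(OC)c(OC)c2)cc1` keeps the rest of compound 2 and replaces the group on the sulfur, bringing in 6-methoxy-1,3-benzothiazol-2-yl: a group of 11 heavy atoms (8 carbon, 1 nitrogen, 1 oxygen, 1 sulfur; one five-membered aromatic ring with 2 hetero atoms, one six-membered aromatic ring of carbon only) in place of a group of 6 heavy atoms (4 carbon, 2 nitrogen; one five-membered non-aromatic ring with 2 hetero atoms), on a sulfur. For the measured compounds named here, one measured step bears on this, also an exchange on that sulfur: a 1.2-fold higher number from compound 1 to compound 2 (0.09 log units; within the scatter). That step brought in no group as large as the one entering here, so it is only a weak guide. No step beyond the scatter is therefore expected in this assay, in either direction, though the uncertainty is wide. The expected change is a 1.2-fold lower number from compound 2 to compound 3 (0.09 log units; within the scatter). For compound 3 the estimated value is 2400 nM, with an expected range of 700 nM to 8000 nM.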

Compound 3, half-maximal inhibitory concentration: 1270 nM
Estimate against measurement, compound 3: 1.9-fold (0.28 log units) above; measured number inside the range.
By their numbers in this assay, from the lowest: compounds 3, 1 and 2 (each within the scatter of the next, the first and the last beyond it).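

In this assay, for the compounds shown here, the group on the sulfur proves able to move the read-out beyond the scatter: the exchange for 6-methoxy-1,3-benzothiazol-2-yl gives a 2.3-fold lower number from compound 2 to compound 3 (0.37 log units; beyond the scatter) and is the first step to do so. The same group entering in place of pyridin-2-yl gives a 1.9-fold lower number from compound 1 to compound 3 (0.28 log units; within the scatter) and stays within the scatter, so the change counts against only one of the two earlier groups, and the larger group brings no gain that holds against both. No measurement at hand gives a reason for this difference between the two steps.

The compounds shown leave open whether the methoxy group matters, or whether a plain 1,3-benzothiazol-2-yl, or one carrying a chlorine or an amine instead, would give a similar number. They also leave open how an oxygen or a methylene in place of the sulfur itself would read.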